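Replacing the Heteroaryl Amide of Compound 2: An Expectation

The compounds below may be only part of what the source reports. "The series", "measured", "known", "first", "only" and "open" are said of these compounds alone.

Compound 1 `O=C(CCCCCCNC(=O)C(O)(O)C(F)(F)F)Nc1nc2ccc(Br)cc2o1`: 12100 nM
Compound 2 `O=C(CCCCCCNC(=O)C(O)(O)C(F)(F)F)Nc1nc2ccccc2s1`: 2370 nM
Compound 3 `O=C(CCCCCCNC(=O)C(O)(O)C(F)(F)F)Nc1nc2ccc(Br)cc2s1`: 10300 nM

All three compounds share a long chain ending in a hydrated trifluoromethyl ketone and were tested in a functional assay on HCT-116 cells (Homo sapiens) for inhibition, read by colorimetric assay, with a stated time of 3 days; a lower number here means a stronger inhibitor, a higher number a weaker inhibitor. Compound 2 stands lowest of the three numbers, meaning the strongest inhibition seen so far. The nearest measured neighbour is compound 3, and the step of a 4.3-fold higher number from compound 2 to compound 3 (0.64 log units; beyond the scatter) comes from putting bromo in place of hydrogen on an aromatic carbon. Compound 1, which carries the same bromo on a different bicyclic core, gives a still higher number in this assay than compound 2.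

Compound 4 `COc1ccccc1NC(=O)CCCCCCNC(=O)C(O)(O)C(F)(F)F` is the new compound. It differs from compound 2 in one place: 2-methoxyphenyl in place of 1,3-benzothiazol-2-yl on an amide-type nitrogen. Among the compounds with values here, no measured step touches this part of the molecule; the only step known concerns the bromo substituent, so it offers no direct guide. Within the data shown here, the pattern among the three measured compounds shows only that changes on the aromatic end shift the number by modest amounts, and in both known cases upward from compound 2.

On that basis compound 4 is expected to give a higher number than compound 2, roughly 6000 nM, within a range from 1200 nM to 30000 nM. The expected step is a 2.5-fold higher number from compound 2 to compound 4 (0.40 log units; beyond the scatter).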

Compound 4, half-maximal inhibitory concentration: 10100 nM
Compound 4: middle estimate off by 1.7-fold (0.23 log units), on the low side; the range from low to high includes it.
By their numbers in this assay, from the lowest: compound 2; then compounds 4, 3 and 1 (each within the scatter of the next).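

Swapping 1,3-benzothiazol-2-yl for 2-methoxyphenyl on the amide-type nitrogen gives a 4.3-fold higher number from compound 2 to compound 4 (0.63 log units; beyond the scatter) in this assay. Within the data shown here, this is the first view of what happens when the whole group at this position is exchanged, whereas the earlier step only added a bromo to the group already there. The result shows that inhibition in these cells does not depend entirely on 1,3-benzothiazol-2-yl, as a single six-membered carbon ring carrying a methoxy still gives a measurable number, yet of these two groups 1,3-benzothiazol-2-yl gives the stronger inhibitor. Nothing available here explains why the number rises with this exchange.

This single step removes the five-membered ring with its two hetero atoms and introduces the methoxy together, so the part played by each remains unresolved. A plain phenyl would isolate the contribution of the methoxy, while a phenyl carrying an amine or a carboxylic acid would show how far the number at this position can move with other groups on that ring.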